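Fibroblast tolerance of a benzothiophenyl analogue of compound 3

This account rests on a few compounds, and the source may have more. Where it says the series, first, only, none or still open, it means among the compounds named here.

Compound 1 `CCC(CC)O[C@@H]1C=C(C(=O)O)C[C@H](NCc2cccc(OC)c2)[C@H]1NC(C)=O`: > 200000 nM
Compound 2 `CCC(CC)Oc1cccc(CN[C@H]2CC(C(=O)O)=C[C@@H](OC(CC)CC)[C@@H]2NC(C)=O)c1`: > 200000 nM
Compound 3 `CCC(CC)O[C@@H]1C=C(C(=O)O)C[C@H](NCc2ccc(Oc3ccccc3)cc2)[C@H]1NC(C)=O`: > 200000 nM

In an ADME assay on cells (Fibroblast, Gallus gallus) for cytotoxicity, read by CCK-8 assay, with a stated time of 48 h (a higher number here means that more compound is tolerated, a lower number that less compound is tolerated), compound 1 reaches only a limit of the assay, > 200000 nM. In this assay compound 2 likewise reaches only a limit, > 200000 nM. Compound 3 also gives only a limit in this assay, > 200000 nM. Within the data shown here, the single step between neighbours, a step that the two limits leave unreadable from compound 1 to compound 2, therefore cannot be read, and all three values sit where the limit of > 200000 nM in this assay, at which 3 of the 3 values shown sit, describes. Compound 3 thus stands at the same limit as the other two compounds shown, with no number beneath it.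

Compound 4 `CCC(CC)O[C@@H]1C=C(C(=O)O)C[C@H](NCc2ccc(-c3csc4ccccc34)cc2)[C@H]1NC(C)=O` differs from compound 3 in one place: 1-benzothiophen-3-yl in place of phenoxy on an aromatic carbon. Among the measured compounds shown here, no measured step bears directly on this change, and the one step that exists is itself unreadable, so no size or direction can be inferred beyond the scatter of this assay. Because every value shown sits at the limit described by the limit of > 200000 nM in this assay, at which 3 of the 3 values shown sit, compound 4 is expected to remain near that limit, with an estimated step of a number no higher from compound 3 to compound 4 (the limit leaves the size open). The estimate for compound 4 in this assay is 200000 nM, ranging from 70000 nM to 500000 nM.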

Compound 4, half-maximal cytotoxic concentration: > 200000 nM
Compound 4 was reported as a limit; the forecaster's own chance of this, stated with the estimate: 70%; the middle value lies on the limit itself.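

Compound 4 gives only a limit in this assay, > 200000 nM. Compound 3 also stands at a limit, so no step can be read between compound 3 and compound 4. Where the half-maximal cytotoxic concentration of any of the compounds shown actually lies remains open: the limit of > 200000 nM in this assay, at which 4 of the 4 values shown sit.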